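A few compounds are considered here, and "the series" means these few. Any claim that something is new, unique, unknown or untested is made for them only; others in the source may bear on it.

Compound 3 `CCOC(=O)[C@@H]1CCCN(S(=O)(=O)c2ccc(S(=O)(=O)N(C)C)cc2)C1` carries a dimethylsulfamoyl group on the aromatic ring of its core. In a functional assay on MIA PaCa-2 cells (Homo sapiens) for inhibition, read by MTT assay, with a stated time of 3 days (a lower number here means a stronger inhibitor, a higher number a weaker inhibitor), compound 3 reaches only a limit, > 10000 nM. Two measured neighbours share that core and vary the same sulfamoyl group. Compound 1 `CCOC(=O)[C@@H]1CCCN(S(=O)(=O)c2ccc(S(=O)(=O)N3CCOCC3)cc2)C1` bears a morpholin-4-yl group there, and in this assay compound 1 also gives only a limit, > 10000 nM. Compound 2 `CCOC(=O)[C@@H]1CCCN(S(=O)(=O)c2ccc(S(=N)(=O)N(CC)CC)cc2)C1` bears a diethylsulfonimidoyl group, and in this assay compound 2 again gives only a limit, > 10000 nM. All three values sit at the limit of > 10000 nM in this assay, at which 3 of the 3 values shown sit, so the steps between them cannot be read: a step that the two limits leave unreadable from compound 1 to compound 3, a step that the two limits leave unreadable from compound 2 to compound 3 and a step that the two limits leave unreadable from compound 1 to compound 2.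

Compound 4 `CCOC(=O)[C@@H]1CCCN(S(=O)(=O)c2ccc(S(=O)(=O)N(CC)C(C)C)cc2)C1` has not yet been measured. It differs from compound 3 by ethyl(isopropyl)amino in place of dimethylamino on a sulfonyl sulfur. Among the compounds with values here, the steps that bear on this change are those from compound 1 and compound 2 to compound 3, both of which alter the group on the sulfonyl sulfur and both of which are unreadable, since each joins two limits. No readable step is therefore available, and the expected outcome is again no reading beyond the limit. Compound 4 is estimated to give 15000 nM, within 5000 nM to 50000 nM, which would mean an expected step that the limit leaves unreadable from compound 3 to compound 4.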

Compound 4, half-maximal inhibitory concentration: > 10000 nM
Compound 4: a limit, no number; the forecaster's own chance of this, stated with the estimate: 85%; the middle value is on the limit's open side.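

Compound 4 also reaches only a limit in this assay, so none of its steps from compound 1, compound 2 or compound 3 can be read, as each joins two limits: the limit of > 10000 nM in this assay, at which 4 of the 4 values shown sit.

The compounds shown leave open whether any group on the sulfonyl sulfur of the shared core can give a numerical reading in this assay.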